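The compounds below may be only part of what the source reports. "The series", "measured", "known", "first", "only" and "open" are said of these compounds alone.

Measured compounds:
- compound 1, `CC(C)C[C@H](N)CN(C(=O)[C@@H]1C[C@H]1c1ccccc1)c1ccc(-c2cccs2)cc1`, in a functional assay for agonist activity at G protein-coupled receptor 88 (Homo sapiens), read by HTRF and cAMP accumulation (a higher number here means that more compound is needed for the effect, a lower number that less compound is needed), gives 1500 nM
- compound 2, `CC(C)C[C@H](N)CN(C(=O)[C@@H]1C[C@H]1c1ccccc1)c1ccc(C2=CCCC2)cc1`, in this assay gives 1200 nM
- compound 3, `CC(C)C[C@H](N)CN(C(=O)[C@@H]1C[C@H]1c1ccccc1)c1ccc(-c2ccc(F)cc2)cc1`, in this assay gives 900 nM

All three share the same core and differ only in the group on the aromatic carbon of the terminal ring. Compound 3 gives the lowest of the three numbers in this assay, but its gaps to the others are small: a 1.3-fold lower number from compound 2 to compound 3 (0.12 log units; within the scatter) and a 1.7-fold lower number from compound 1 to compound 3 (0.22 log units; within the scatter), both inside the scatter, as is a 1.3-fold lower number from compound 1 to compound 2 (0.10 log units; within the scatter). On these numbers the three compounds cannot be ordered.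

Compound 4, `CC(C)C[C@H](N)CN(C(=O)[C@@H]1C[C@H]1c1ccccc1)c1ccc(-c2cccc(C#N)c2)cc1`, is the next member. The change is 3-cyanophenyl in place of 4-fluorophenyl on an aromatic carbon. For the measured compounds named here, no measured step swaps one substituted phenyl for another substituted phenyl; the nearest precedents are the three exchanges among thiophen-2-yl, cyclopent-1-en-1-yl and 4-fluorophenyl, each of which moved this assay by less than the scatter. A step of similar size, with no clear direction, is therefore expected from compound 3 to compound 4: a 1.1-fold higher number from compound 3 to compound 4 (0.05 log units; within the scatter). Compound 4 is estimated at 1000 nM, with a range from 400 nM to 2500 nM.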

Compound 4, half-maximal effective concentration: 4500 nM
Beside the measured number, compound 4's estimate is 4.5-fold (0.65 log units) below it, and the stated range ends below it.
By their numbers in this assay, from the lowest: compounds 3, 2 and 1 (each within the scatter of the next); then compound 4.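

In this assay this position, on an aromatic carbon para to a large group, no longer looks indifferent to what it carries: the three earlier exchanges stayed within the scatter, whereas 3-cyanophenyl gives a 5.0-fold higher number from compound 3 to compound 4 (0.70 log units; beyond the scatter) and a 3.8-fold higher number from compound 2 to compound 4 (0.57 log units; beyond the scatter) and a 3.0-fold higher number from compound 1 to compound 4 (0.48 log units; beyond the scatter) as well. All three steps run towards more compound being needed, so compound 4 stands apart from compounds 1, 2 and 3, which remain unordered among themselves. The step from compound 3 to compound 4 changes both the substituent on the phenyl ring and its place there, and these two changes cannot be separated on these numbers.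

No evidence bears on the reason for this rise. Still open, as far as these compounds go, is whether the nitrile or its place matters more, which 4-cyanophenyl and 3-fluorophenyl could show, and how an aminomethyl or carboxylic acid group on the same phenyl ring would read.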